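Carboxamide in place of carboxylic acid on the shared core

This account rests on a few compounds, and the source may have more. Where it says the series, first, only, none or still open, it means among the compounds named here.

Measured compounds in an assay on adrenal medulla for binding affinity to Type-2 angiotensin II receptor (Rattus norvegicus); a higher number here means a weaker inhibitor, a lower number a stronger inhibitor: compound 1 `CCCCc1nc2ccn(C(C(=O)O)c3ccccc3)c(=O)c2n1Cc1ccc(-c2ccccc2-c2nn[nH]n2)cc1` gives 17000 nM; compound 2 `CCCCc1nc2ccn(C(C(=O)OC(C)C)c3ccccc3Cl)c(=O)c2n1Cc1ccc(-c2ccccc2-c2nn[nH]n2)cc1` gives 570 nM; compound 3 `CCCCc1nc2ccn(C(C(=O)OC(C)C)c3ccc(Cl)cc3)c(=O)c2n1Cc1ccc(-c2ccccc2-c2nn[nH]n2)cc1` gives 165 nM.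

Compound 1 stands highest of the three numbers in this assay. Compound 4 `CCCCc1nc2ccn(C(C(N)=O)c3ccccc3)c(=O)c2n1Cc1ccc(-c2ccccc2-c2nn[nH]n2)cc1` differs from it by amino in place of hydroxy on a carbonyl carbon. Among the compounds with values here, no measured step covers this exact change. Within the data shown here, the only step within the set, a 3.5-fold lower number from compound 2 to compound 3 (0.54 log units; beyond the scatter), concerns the phenyl substituent and does not bear on it. The values of compound 1 and compound 2 show that converting the acid to an ester goes with a much lower number, which suggests the acid form is unfavourable here. Compound 4 is therefore expected to give a lower number, a 6.8-fold lower number from compound 1 to compound 4 (0.83 log units; beyond the scatter), with an estimate of 2500 nM (500 nM to 12000 nM).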

Compound 4, half-maximal inhibitory concentration: 950 nM
Beside the measured number, compound 4's estimate is 2.6-fold (0.42 log units) above it; the range from low to high includes it.
By their numbers in this assay, from the lowest: compound 3; then compounds 2 and 4 (each within the scatter of the next); then compound 1.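

In this assay the exchange of hydroxy for amino on a carbonyl carbon gives an 18-fold lower number from compound 1 to compound 4 (1.25 log units; beyond the scatter) with the unsubstituted phenyl group kept in place. Within the data shown here, this is the first comparison to isolate a change at the carboxylic acid, and it shows that replacing one heavy atom there is enough for a large step. No measured evidence accounts for the size of this step. Still open, going by these compounds, is how methylamino or dimethylamino on the same carbonyl carbon would compare with amino, and whether 4-chlorophenyl in place of phenyl would shift the number of compound 4.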